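Clearance notes: aryl swap on the core of compound 2

The source may report more compounds than this note shows. Statements on the series, on what has been measured and on what is new or still open speak of the compounds shown alone.

Among the compounds with values here, in an in vitro ADME assay on microsomes from liver (Homo sapiens) for metabolic stability (a lower number here means slower removal, a higher number faster removal of the compound), compound 1 (`O=C(COCc1ccccc1)N1CCN(c2ccncc2)CC1`) has the entry "not determined" (no result reported), so compound 2 (`O=C(COCc1ccncc1)N1CCN(c2ccc(Cl)cc2F)CC1`), at 38 mL.min-1.g-1, holds the only number and has no measured neighbour to rank against. Compound 3 (`O=C(COCc1ccncc1)N1CCN(c2cc(Cl)ccn2)CC1`) carries 4-chloropyridin-2-yl in place of 4-chloro-2-fluorophenyl on an amine nitrogen in a ring. Within the data shown here, no measured step is available to scale this change, so only a modest fall in this assay is expected, possibly no larger than the usual scatter. The expected step is a 1.5-fold lower number from compound 2 to compound 3 (0.18 log units; within the scatter). For compound 3 the estimated value is 25 mL.min-1.g-1, with an expected range of 10 mL.min-1.g-1 to 55 mL.min-1.g-1.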

Compound 3, intrinsic clearance in microsomes: 4 mL.min-1.g-1
Compound 3: middle estimate off by 6.3-fold (0.80 log units), on the high side; measured number below the stated range.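

In this assay, the aryl group on the amine nitrogen in a ring proves a strong lever: 4-chloropyridin-2-yl in place of 4-chloro-2-fluorophenyl gives a 9.5-fold lower number from compound 2 to compound 3 (0.98 log units; beyond the scatter). Within the data shown here, this is the first measured step, and it lies beyond the scatter. Nothing on hand accounts for its size.

The swap adds a ring nitrogen and removes the fluorine at once, so the two changes cannot be separated. As far as these compounds go, it remains open how a methoxy group in place of the chlorine on the pyridine would read.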